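From hydroxy to ethylamino in an antiproliferative series

This account rests on a few compounds, and the source may have more. Where it says the series, first, only, none or still open, it means among the compounds named here.

Compound 1 `COc1ccc(C(=O)c2ccc(OC)c3c2OC(C)(C)C=C3)c(NC(=O)CBr)c1` gives 1210 nM
Compound 2 `C=C(c1ccc2c(c1)C=CC(C)(C)O2)c1ccc(OC)cc1NC(=O)CO` gives 40 nM
Compound 3 `C=C(c1ccc(OC)cc1NC(=O)CNC)c1ccc(OC)c2c1OC(C)(C)C=C2` gives 150 nM

In a functional assay on A549 cells (Homo sapiens) for antiproliferative activity, read by MTT assay, with a stated time of 48 h (on this read-out lower numbers stand for stronger inhibition and higher numbers for weaker inhibition), compound 2 has the lowest number of the three, 40 nM, and so shows the strongest inhibition. The gaps up to compound 3 and to compound 1 both lie beyond the scatter, which makes compound 2 the natural reference point.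

Compound 4 `C=C(c1ccc2c(c1)C=CC(C)(C)O2)c1ccc(OC)cc1NC(=O)CNCC` matches compound 2 except in one place: ethylamino in place of hydroxy on a saturated chain carbon bound to a carbonyl carbon. For the measured compounds named here, no pair of measured compounds shows this change directly. The closest guide is compound 3, which also has a nitrogen on that chain carbon, though on a different core, and it gives 150 nM in this assay. That single value cannot separate the contribution of the chain from that of the core, so it is only a loose guide.

On that basis, a 3.0-fold higher number from compound 2 to compound 4 (0.48 log units; beyond the scatter) is expected to be a rise in the number, meaning weaker inhibition, and is estimated to lie modestly beyond the scatter. For compound 4 the estimated value is 120 nM, with an expected range from 40 nM to 360 nM.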

Compound 4, half-maximal inhibitory concentration: 1180 nM
Beside the measured number, compound 4's estimate is 9.8-fold (0.99 log units) below it; measured number above the stated range.
By their numbers in this assay, from the lowest: compound 2; then compound 3; then compounds 4 and 1 (each within the scatter of the next).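

In this assay, putting ethylamino in place of hydroxy on a saturated chain carbon bound to a carbonyl carbon weakens inhibition by a large margin (a 30-fold higher number from compound 2 to compound 4 (1.47 log units; beyond the scatter)). This is the only change among these compounds that can be read on its own, as the earlier compounds differ from one another in more than one place, and it shows that activity in this series depends strongly on the group at this position. The group that leaves and the group that enters each count one hydrogen-bond donor and one hydrogen-bond acceptor, and neither carries a net charge. No measurement here explains the loss.

The compounds shown leave open whether the step comes from the nitrogen or from the two added carbons of the ethyl group. A plain amino group or a methoxy group in the same place, on the core shared by compound 2 and compound 4, would help to tell these two apart.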